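The source may report more compounds than this note shows. Statements on the series, on what has been measured and on what is new or still open speak of the compounds shown alone.

Two compounds share one core and differ only in a small appendage. Compound 1 `CC(C)(C)n1cc2c(n1)C(=O)CC1(CCN(C(=O)c3cc(-c4ccccc4)nc4ccccc34)CC1)O2` gives 1940 nM in a functional assay on A549 cells (Homo sapiens) for inhibition, read by MTT assay, with a stated time of 72 h (on this read-out higher numbers stand for weaker inhibition and lower numbers for stronger inhibition), and compound 2 `CC(C)(C)n1cc2c(n1)C(=O)CC1(CCN(C(=O)c3cc(-c4ccc(F)cc4)nc4ccccc34)CC1)O2` gives 5770 nM. Among the measured compounds shown here, the step of a 3.0-fold higher number from compound 1 to compound 2 (0.47 log units; beyond the scatter) is the only measured change, and it leaves compound 2 with the higher of the two numbers, the weaker inhibitor of the pair.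

Compound 3 `CC(C)Oc1cc(C(=O)N2CCC3(CC2)CC(=O)c2nn(C(C)(C)C)cc2O3)c2ccccc2n1` carries a different kind of change: isopropoxy in place of 4-fluorophenyl on an aromatic carbon. The whole 4-fluorophenyl group, the very group touched by the earlier step, is removed and replaced by an isopropoxy chain at the same place. The measured step from compound 1 to compound 2 concerned a single fluorine on that phenyl ring; it does not tell how the ring's removal, or an isopropoxy chain in its place, will act. For the measured compounds named here, no measured step bears directly on this change, so the direction is open and the range must be wide. Compound 3 is expected to give about 4000 nM, within a range from 1000 nM to 20000 nM. This estimate means a step of a 1.4-fold lower number from compound 2 to compound 3 (0.16 log units; within the scatter).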

Compound 3, half-maximal inhibitory concentration: > 10000 nM
Compound 3: only a limit was reported (the forecaster's own chance of this, stated with the estimate: 10%); at least 2.5-fold (0.39 log units) between middle value and limit.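

Compound 3 gives no number, only a limit of the assay: the limit of > 10000 nM in this assay, at which 1 of the 3 values shown sits.

Even so, replacing the unsubstituted phenyl ring with isopropoxy on this carbon, next to the ring nitrogen, gives an at least 5.1-fold higher number from compound 1 to compound 3 (0.71 log units; beyond the scatter), which shows that exchanging the whole group, and not just adding a fluorine to it, can weaken inhibition in this assay. From the compounds shown here alone, replacing 4-fluorophenyl with isopropoxy gives an at least 1.7-fold higher number from compound 2 to compound 3 (0.23 log units; that floor lies within the scatter), but that floor alone does not separate the two compounds, and the true size of the gap stays unknown.

The compounds shown cannot tell whether the weaker inhibition comes from losing the aromatic ring or from the isopropoxy chain that takes its place, as the two changes happen together in this single swap. Going by these compounds, a pyridine ring on this carbon would keep an aromatic ring in place, while an amine such as dimethylamino or a longer chain such as butoxy would not, so these groups remain open tests of how much this position depends on an aromatic ring.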